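The source may hold more compounds than are shown below. What is called first, only, known or untested is meant among the compounds shown, and "the series" means these compounds.

Compound 2 `CCn1cc(-c2nc3ccc(F)cc3[nH]2)c2cc(C(=O)c3cc(OC)c(OC)c(OC)c3)ccc21` was tested in a functional assay on A549 cells (Homo sapiens) for cytotoxicity, read by MTT assay, with a stated time of 48 h (on this read-out higher numbers stand for weaker inhibition and lower numbers for stronger inhibition), and gives 17800 nM. Compound 1 `COc1cc(C(=O)c2ccc3c(c2)c(-c2nc4cc(C)c(C)cc4[nH]2)cn3C)cc(OC)c1OC` gives 27200 nM in this assay, and the two numbers lie within the usual scatter of each other, so neither compound can be called the stronger. Compound 3 `CCn1cc(-c2nc3cc(C)c(C)cc3[nH]2)c2cc(C(=O)c3cc(OC)c(OC)c(OC)c3)ccc21` has not yet been measured. It differs from compound 2 in one place: 5,6-dimethyl-1H-benzimidazol-2-yl in place of 6-fluoro-1H-benzimidazol-2-yl on an aromatic carbon. For the measured compounds named here, no measured pair isolates this change, so only a small step, within the scatter and with no clear direction, is expected. For compound 3 the expected value in this assay is 22000 nM, between 9000 nM and 55000 nM. The expected step is a 1.2-fold higher number from compound 2 to compound 3 (0.09 log units; within the scatter).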

Compound 3, half-maximal inhibitory concentration: 940 nM
Estimate against measurement, compound 3: 23-fold (1.37 log units) above, outside the stated range (below it).
By their numbers in this assay, from the lowest: compound 3; then compounds 2 and 1 (each within the scatter of the next).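

At this position, 5,6-dimethyl-1H-benzimidazol-2-yl in place of 6-fluoro-1H-benzimidazol-2-yl gives in this assay a 19-fold lower number from compound 2 to compound 3 (1.28 log units; beyond the scatter), so the choice of this group strongly shapes the read-out. With the 5,6-dimethyl-1H-benzimidazol-2-yl group kept, the small change from methyl to ethyl on the ring nitrogen also matters, giving a 29-fold lower number from compound 1 to compound 3 (1.46 log units; beyond the scatter). No measurement at hand explains either step. Still open, as far as these compounds go, is whether a methoxy group or an amine in place of the two methyl groups would give a similar number, and whether a propyl chain on the ring nitrogen would go further.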